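The source may report more compounds than this note shows. Statements on the series, on what has been measured and on what is new or still open speak of the compounds shown alone.

Compound 3, with the structure `Cc1nc(-c2ccc3c(c2)c(C#N)cn3CCNS(C)(=O)=O)sc1C(=O)O`, sits at the bottom of a small set of three in a functional assay on the whole organism (strain Sprague-Dawley) for inhibition, with Rattus norvegicus as the target, with a stated time of 1 h, at a dose of 10 mg/kg by the oral route; on this read-out higher numbers stand for more inhibition at the one dose given (going by the name of the read-out) and lower numbers for less inhibition. Compound 3 gives 0%, and compound 2, with the structure `CC(=O)NCCn1cc(C#N)c2cc(-c3nc(C)c(C(=O)O)s3)ccc21`, gives 0%; the two are level, and the step of no change at the digits printed from compound 2 to compound 3 (within the scatter) lies within the scatter. For the measured compounds named here, compound 1, with the structure `COCC(C)n1cc(C#N)c2cc(-c3nc(C)c(C(=O)O)s3)ccc21`, gives 14.1%, the only number clearly apart from the other two, so the step of a number 14.1 percentage points lower from compound 1 to compound 3 (beyond the scatter) is the one real movement seen so far.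

Compound 4, with the structure `Cc1nc(-c2ccc3c(c2)c(C#N)cn3Cc2ccc(F)cc2F)sc1C(=O)O`, differs from compound 3 in one place: 2,4-difluorophenyl in place of (methanesulfonamido)methyl on a saturated chain carbon bound to an aromatic nitrogen. Of the measured steps, only a number 14.1 percentage points lower from compound 1 to compound 3 (beyond the scatter) bears on this change, and it ran downward when the methanesulfonamide side chain entered. Going by the values given here, no measured compound carries an aromatic ring on this chain carbon, so the entering group has no precedent here. Compound 4 is therefore expected to show a step of a number 12 percentage points higher from compound 3 to compound 4 (beyond the scatter), a modest gain. The estimate for compound 4 is 12%, with a range from 0% to 40%.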

Compound 4, a percentage reported as inhibition, in the whole organism at one dose (the size of the read-out at that dose, not a potency): 16%
For compound 4 the middle estimate is 4 percentage points below the measured one; low and high end bracket the measured number.
By their numbers in this assay, from the lowest: compounds 2 and 3 (each within the scatter of the next); then compounds 1 and 4 (each within the scatter of the next).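

In this assay, the 2,4-difluorobenzyl group on the aromatic nitrogen lifts the number clear of the two compounds with amide-type side chains: a number 16 percentage points higher from compound 3 to compound 4 (beyond the scatter), and likewise a number 16 percentage points higher from compound 2 to compound 4 (beyond the scatter). An aromatic ring on this saturated chain carbon is therefore compatible with a measurable effect at this dose, while a number 1.9 percentage points higher from compound 1 to compound 4 (within the scatter) shows that the 2,4-difluorobenzyl and 1-(methoxymethyl)ethyl groups cannot be told apart here. Nothing available explains why the 2-acetamidoethyl and 2-(methanesulfonamido)ethyl compounds stay lower.

The compounds shown leave open whether the gain needs the two fluorines, which a plain benzyl group or a 4-fluorobenzyl group would test. They also do not show how a basic side chain such as 2-aminoethyl or a longer unbranched alkyl chain would behave at this nitrogen.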